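The compounds below may be only part of what the source reports. "The series", "measured", "known", "first", "only" and "open" are said of these compounds alone.

Among the measured compounds shown here, compound 3, `COC(=O)c1ccc(OCCCCOc2ccc(C(=O)CC3CCCC3)c(O)c2C)cc1`, gives in an assay on HEK293 cells for positive allosteric modulation of metabotropic glutamate receptor 3 (Rattus norvegicus), read by thallium flux, with a stated time of 2.5 min (a lower number here means a smaller maximal response, a higher number a larger maximal response), a largest response of 22%, the lowest of the three numbers measured so far. Compound 1, `Cc1c(OCCCCOc2ccc(C(=O)O)cc2)ccc(C(=O)CC2CCCC2)c1O`, gives 26.7%; the step of a number 4.7 percentage points lower from compound 1 to compound 3 (within the scatter) lies within the scatter, so the two are not told apart by this assay. For the measured compounds named here, compound 2, `Cc1cc(C(=O)O)ccc1OCCCCOc1ccc(C(=O)CC(C)C)c(O)c1C`, gives 42.1%, a number beyond the scatter above compound 3, but compound 2 differs from compound 3 in more than one place and no single step connects them.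

Compound 4, `Cc1c(OCCCCOCOc2ccc(C(=O)O)cc2)ccc(C(=O)CC2CCCC2)c1O`, differs from compound 3 in this way: (4-carboxyphenoxy)methyl in place of 4-(methoxycarbonyl)phenyl on an oxygen on a saturated carbon. The change has two parts. The methyl on the oxygen of the ester is removed, returning to the acid seen in compound 1, and a further saturated carbon and oxygen are added into the chain. Only the first part is covered by a measured step, a number 4.7 percentage points lower from compound 1 to compound 3 (within the scatter), which was within the scatter. Nothing measured here speaks to the lengthening of the chain, so no direction can be claimed for it.

The expectation is therefore a step of a number 5 percentage points higher from compound 3 to compound 4 (within the scatter), within the scatter. Compound 4 is estimated to give 27%, with a range from 14% to 42%.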

Compound 4, largest response reached (reported as percent of maximum), in percent of the reference or control that the assay uses: 46.9%
Estimate against measurement, compound 4: 19.9 percentage points below, and the stated range ends below it.
By their numbers in this assay, from the lowest: compounds 3 and 1 (each within the scatter of the next); then compounds 2 and 4 (each within the scatter of the next).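

In this assay, among the compounds shown here, compound 1 and compound 4 both carry the carboxylic acid, and putting (4-carboxyphenoxy)methyl in place of 4-carboxyphenyl on an oxygen on a saturated carbon gives a number 20.2 percentage points higher from compound 1 to compound 4 (beyond the scatter), so lengthening the link alone moves the maximal response, which no earlier pair could show. The full change gives a step of similar size, a number 24.9 percentage points higher from compound 3 to compound 4 (beyond the scatter), whereas swapping the acid for the methyl ester alone gives a number 4.7 percentage points lower from compound 1 to compound 3 (within the scatter), so among these compounds the rise goes with the longer link and not with the ester. Nothing available explains why the longer link goes with a larger response.

From the compounds shown here alone, the added stretch brings in both a carbon and an oxygen, so it remains open whether a plain longer chain of saturated carbons, with no extra oxygen, would give the same rise. Also open, going by these compounds, are whether the methyl ester of compound 4 would match its acid, as the ester and acid of the shorter link do, and whether an amide in place of the carboxylic acid would keep the response.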